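A few compounds are considered here, and "the series" means these few. Any claim that something is new, unique, unknown or untested is made for them only; others in the source may bear on it.

In a functional assay on HCT-15 cells (Homo sapiens) for inhibition, read by sulforhodamine B assay, with a stated time of 48 h (on this read-out lower numbers stand for stronger inhibition of growth and higher numbers for weaker inhibition of growth), compound 1 `CCCCCCCCCCCC[C@@H](O)[C@H]1CC[C@H]([C@H](O)CCCCCCCCCCNC(=O)c2ccnn2C)O1` gives 100000 nM, level with compound 3 `CCCCCCCCCCCC[C@@H](O)[C@H]1CC[C@H]([C@H](O)CCCCCCCCCCC(=O)Nc2ccnn2C)O1` at 100000 nM, and these two share the highest of the three numbers. Compound 2 `CCCCCCCCCCCC[C@@H](O)[C@H]1CC[C@H]([C@H](O)CCCCCCCCCCN(C)C(=O)c2ccnn2C)O1` gives 10000 nM. Compound 4 `CCCCCCCCCCCC[C@@H](O)[C@H]1CC[C@H]([C@H](O)CCCCCCCCCCOC(=O)c2ccnn2C)O1` departs from compound 1 in one place: ((1-methyl-1H-pyrazol-5-yl)carbonyl)oxy in place of ((1-methyl-1H-pyrazol-5-yl)carbonyl)amino on a saturated chain carbon, ten or more bonds along the chain from an oxygen on a saturated carbon and a saturated ring carbon. Among the compounds with values here, two measured steps bear on this change. Compound 4 has no amide hydrogen, and replacing that hydrogen with methyl gave a 10-fold lower number from compound 1 to compound 2 (1.00 log units; beyond the scatter), a modest step. Turning the linkage around gave no change at the digits printed from compound 1 to compound 3 (within the scatter), so not every change here moves the number. A modest move toward stronger growth inhibition is therefore expected, an estimated 4.0-fold lower number from compound 1 to compound 4 (0.60 log units; beyond the scatter). The expected value for compound 4 is 25000 nM, with an estimated range of 5000 nM to 100000 nM.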

Compound 4, concentration for 50% growth inhibition: 47900 nM
Beside the measured number, compound 4's estimate is 1.9-fold (0.28 log units) below it, within the range that was stated.
By their numbers in this assay, from the lowest: compound 2; then compound 4; then compounds 1 and 3 (each within the scatter of the next).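

Putting oxygen in place of the amide nitrogen still lowers the number, a 2.1-fold lower number from compound 1 to compound 4 (0.32 log units; beyond the scatter), and the ester compares the same way with the reversed amide, a 2.1-fold lower number from compound 3 to compound 4 (0.32 log units; beyond the scatter). A linkage with no amide hydrogen can therefore lower the number without carrying a methyl, yet the methylated amide keeps the lower number, a 4.8-fold higher number from compound 2 to compound 4 (0.68 log units; beyond the scatter). Nothing measured here explains these steps.

Still open, from the compounds shown here alone, is whether a plain ether, an amine or a sulfonamide at this position would follow the two linkages without an amide hydrogen. Going by these compounds, the effect of a longer or shorter chain on these linkages is also open.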